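The compounds below may be only part of what the source reports. "The series", "measured", "known", "first", "only" and "open" are said of these compounds alone.

Series around a shared core: the core of compound 1 `COc1ccc(CCCN2CCC(COC(c3ccc(Br)cc3)c3ccc(Br)cc3)CC2)cc1` carries a bis-brominated ether arm, compound 2 `COc1ccc(CCCN2CCC(=CCC(c3ccccc3)c3ccccc3)CC2)cc1` an alkene-linked diphenyl arm, compound 3 `CN1CCC(COC(c2ccccc2)c2ccccc2)CC1` the ether arm of compound 1 without bromine and with methyl on the ring nitrogen. In a functional assay on cells (T-cell line, Homo sapiens) for inhibition (a lower number here means a stronger inhibitor, a higher number a weaker inhibitor), compound 1 gives 3200 nM and compound 2 gives 400 nM. Compound 3 reaches only a limit of this assay, > 20000 nM, so no number stands for it. Within these three, compound 3 sits on (the limit of > 20000 nM in this assay, at which 1 of the 3 values shown sits), while compounds 1 and 2 both return measured values.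

Compound 4 `CCCCCCCCCN1CCC(COC(c2ccccc2)c2ccccc2)CC1` differs from compound 3 in one place: octyl in place of hydrogen on a saturated chain carbon bound to an amine nitrogen in a ring. For the measured compounds named here, no step between measured compounds covers this change. What the data offer is that the two compounds with a larger group than methyl on the ring nitrogen both return measured values: compound 1 gives 3200 nM and compound 2 gives 400 nM. Compound 3, with methyl there, stays at its limit. On that basis a gain in potency is expected for compound 4, of a size beyond the usual scatter, though with real chance of another limit. The estimated step of an at least 8.0-fold lower number from compound 3 to compound 4 (0.90 log units; beyond the scatter) is a direction rather than a firm size. Compound 4 is expected at about 2500 nM, within 500 nM to 12000 nM in this assay.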

Compound 4, half-maximal inhibitory concentration: 700 nM
Beside the measured number, compound 4's estimate is 3.6-fold (0.55 log units) above it; the range from low to high includes it.
By their numbers in this assay, from the lowest: compounds 2 and 4 (each within the scatter of the next); then compound 1. At a limit, above all of these: compound 3.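

With octyl in place of hydrogen on a saturated chain carbon bound to an amine nitrogen in a ring, the series now has a change in one place at this position, and in this assay it reads as an at least 28-fold lower number from compound 3 to compound 4 (1.45 log units; beyond the scatter). Compound 1 and compound 2 differ from compound 3 in more than one place, so they could not tie a change in potency to this position alone, whereas compound 4 keeps the ether arm of compound 3 and alters only the chain. Compound 3 stands at a limit of the assay and not at a number, which makes the size of this step a lower bound: the limit of > 20000 nM in this assay, at which 1 of the 4 values shown sits.

Open, going by these compounds, is how the number moves with butyl or dodecyl in place of nonyl on the amine nitrogen in a ring, and whether it follows chain length in any regular way. Also open, on these data alone, is whether an amine or a carboxylic acid at the end of the nonyl chain would hold the potency of compound 4 at 700 nM.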